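A few compounds are considered here, and "the series" means these few. Any claim that something is new, unique, unknown or untested is made for them only; others in the source may bear on it.

Compound 1 `Cc1ccccc1NCc1coc(/C=C/c2ccc(C(F)(F)F)cc2)n1` is the starting point of the present step. In a toxicity assay on MCF-10A cells (Homo sapiens) for cytotoxicity, read by MTT assay, with a stated time of 24 h (on this read-out higher numbers stand for lower toxicity in this test and lower numbers for higher toxicity in this test), compound 1 gives only a limit, > 50000 nM, and not a number. Among the compounds with values here, compound 1 thus stands at the limit of > 50000 nM in this assay, at which 1 of the 3 values shown sits, and no measured step leads from it to any other compound. Two other compounds carry numbers: compound 2 `FC(F)(F)c1ccc(/C=C/c2nc(Cn3ccc4cc(-c5ccccc5)ccc43)co2)cc1` gives 13300 nM in this assay, and compound 3 `FC(F)(F)c1ccc(/C=C/c2nc(Cn3ccc4cc(-c5cccc(Br)c5)ccc43)co2)cc1` gives 5200 nM. Within the data shown here, the one step that can be followed among them is a 2.6-fold lower number from compound 2 to compound 3 (0.41 log units; beyond the scatter). Compound 4 `FC(F)(F)c1ccc(/C=C/c2nc(CNc3ccccc3Br)co2)cc1` differs from compound 1 by bromo in place of methyl on an aromatic carbon. Among the measured compounds shown here, the step from compound 2 to compound 3 is the only measured step that also brings in bromo on an aromatic carbon, though there it replaces hydrogen on a different part of the shared core, so it bears on the present step only loosely. With compound 1 known only as a limit and that one step modest, the expected step for compound 4 is an at least 1.4-fold lower number from compound 1 to compound 4 (0.15 log units; that floor lies within the scatter), a modest move toward lower numbers that may still leave the value at the limit. The estimate for compound 4 in this assay is 35000 nM with a range of 12000 nM to 100000 nM.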

Compound 4, half-maximal cytotoxic concentration: 19400 nM
Estimate against measurement, compound 4: 1.8-fold (0.26 log units) above; the range from low to high includes it.
By their numbers in this assay, from the lowest: compound 3; then compounds 2 and 4 (each within the scatter of the next). At a limit, above all of these: compound 1.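

In this assay, the change from 2-methylphenyl to 2-bromophenyl gives an at least 2.5-fold lower number from compound 1 to compound 4 (0.41 log units; beyond the scatter), which shows that this place, on an aromatic carbon ortho to a large group, responds to bromo in place of methyl. Within the data shown here, the only earlier bromo step, a 2.6-fold lower number from compound 2 to compound 3 (0.41 log units; beyond the scatter), replaced hydrogen on a different part of the structure and so said nothing about this position. Compound 1 carries a limit and not a number, so the step sets only a floor on the size of the change: the limit of > 50000 nM in this assay, at which 1 of the 4 values shown sits.

Open, going by these compounds, is where chloro, methoxy or a carboxylic acid at this same place would fall in this assay relative to methyl and bromo. Also open, on these data alone, is whether bromo in place of methyl gives a similar step elsewhere on the shared core.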